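The compounds below may be only part of what the source reports. "The series", "measured", "known", "first", "only" and "open" are said of these compounds alone.

Compound 1 `COc1ccc(C(=O)/C=C/c2ccccc2)c2c1C=CC(C)(C)O2` and compound 2 `COc1ccc(C(=O)/C=C/c2ccsc2)c2c1C=CC(C)(C)O2` share one core and differ only in the aryl group on a double-bonded chain carbon bound to a double-bonded chain carbon. In a functional assay on HT-29 cells (Homo sapiens) for antiproliferative activity, read by MTT assay, with a stated time of 24 h (on this read-out lower numbers stand for stronger inhibition and higher numbers for weaker inhibition), compound 1 gives > 10000 nM, which is a limit of the assay and not a number. In this assay compound 2 gives > 10000 nM, again a limit of the assay. The step that the two limits leave unreadable from compound 1 to compound 2 therefore cannot be sized, which is what the limit of > 10000 nM in this assay, at which 2 of the 2 values shown sit, shows. Compound 3 `COc1ccc(C(=O)/C=C/c2ccccn2)c2c1C=CC(C)(C)O2` carries the next change: pyridin-2-yl in place of thiophen-3-yl on a double-bonded chain carbon bound to a double-bonded chain carbon. No measured step can be read to guide this change; all that is known is that both measured neighbours sit at the limit. Compound 3 is therefore expected to stay weak as well. The step that this estimate means is a step that the limit leaves unreadable from compound 2 to compound 3, and it is expected to be unreadable again. The estimated value for compound 3 in this assay is 15000 nM, in a range from 5000 nM to 50000 nM.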

Compound 3, half-maximal inhibitory concentration: 2120 nM
For compound 3 the middle estimate is 7.1-fold (0.85 log units) above the measured one; measured number outside the range, below it.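

In this assay, for the compounds shown here, pyridin-2-yl on a double-bonded chain carbon bound to a double-bonded chain carbon gives the first value at this position that is a number, with an at least 4.7-fold lower number from compound 2 to compound 3 (0.67 log units; beyond the scatter) and an at least 4.7-fold lower number from compound 1 to compound 3 (0.67 log units; beyond the scatter). The aryl group at this position can therefore move the read-out, which the earlier pair could not show, since the step between compound 1 and compound 2 cannot be read. Both new steps are only lower bounds on the size of the change, because each starts from a limit of the assay and not from a number: the limit of > 10000 nM in this assay, at which 2 of the 3 values shown sit.

The compounds shown leave open whether the gain belongs to pyridin-2-yl alone or would also appear with pyridin-4-yl or a pyrimidine ring. They also leave open what an amine on the pyridine ring would do to the value of compound 3.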